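Ring-size change at the thiocarbonyl nitrogen in a benzamide series

This account rests on a few compounds, and the source may have more. Where it says the series, first, only, none or still open, it means among the compounds named here.

Measured compounds:
- compound 1 `Nc1ccccc1NC(=O)c1ccc(CSC(=S)N2CCN(C3CCCCC3)CC2)cc1`: 76.1%
- compound 2 `CC1CCCCN1C(=S)SCc1ccc(C(=O)Nc2ccccc2N)cc1`: 76.3%
- compound 3 `COc1ccc(N2CCN(C(=S)SCc3ccc(C(=O)Nc4ccccc4N)cc3)CC2)cc1`: 52.3%

In a functional assay on HeLa cells (Homo sapiens) for antiproliferative activity, read by CCK-8 assay, with a stated time of 72 h, tested at 8 uM (on this read-out higher numbers stand for a stronger effect at the one concentration tested and lower numbers for a weaker effect), compound 2 gives the highest of the three numbers, but compound 1 sits within the scatter of it, so the two cannot be ordered. Compound 3 stands clearly lower. For the measured compounds named here, the one step that is resolved in this set, a number 23.8 percentage points lower from compound 1 to compound 3 (beyond the scatter), concerns a substituent on an amine nitrogen in a ring, not the ring itself.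

Compound 4 `Nc1ccccc1NC(=O)c1ccc(CSC(=S)N2CCCC2)cc1` differs from compound 2 by pyrrolidin-1-yl in place of 2-methylpiperidin-1-yl on a thiocarbonyl carbon. Going by the values given here, no measured step alters the ring that is attached to the thiocarbonyl carbon, so there is nothing that bears directly on this change. Compound 1 and compound 2 carry different six-membered rings at this position and give numbers within the scatter of each other, which is the only hint available: the read-out has so far tolerated a change of the ring on the thiocarbonyl carbon. The step of a number 6.3 percentage points lower from compound 2 to compound 4 (within the scatter) is therefore expected to be small, most likely none beyond the scatter, with a slight lean downward given that the largest move in the set was a loss.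

Compound 4 is estimated at 70%, with a range from 52% to 82%.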

Compound 4, a percentage reported as inhibition, at one concentration (the size of the read-out at that concentration, not a potency): 77.8%
Beside the measured number, compound 4's estimate is 7.8 percentage points below it; low and high end bracket the measured number.
By their numbers in this assay, from the lowest: compound 3; then compounds 1, 2 and 4 (each within the scatter of the next).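

In this assay the position on the thiocarbonyl carbon now has its first direct step: a number 1.5 percentage points higher from compound 2 to compound 4 (within the scatter) with pyrrolidin-1-yl in place of 2-methylpiperidin-1-yl. This exchange of a six-membered non-aromatic ring bearing a methyl group for an unsubstituted five-membered non-aromatic ring therefore brings no resolved change in the read-out, and at the one concentration tested the two groups cannot be told apart. Nothing measured in this set bears on the reason for this result.

Whether the read-out would also hold with an open-chain diethylamino group, a morpholin-4-yl ring or a seven-membered azepan-1-yl ring on the thiocarbonyl carbon remains open in the compounds shown. Also open, as far as these compounds go, is whether compound 2 and compound 4 would remain indistinguishable across a full concentration range, a question that a percentage read at one concentration cannot settle.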